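Replacing 4-hydroxyphenyl in compound 2: expected growth inhibition

The source may hold more compounds than are shown below. What is called first, only, known or untested is meant among the compounds shown, and "the series" means these compounds.

Among the compounds with values here, in a functional assay on MDA-MB-231 cells (Homo sapiens) for inhibition, read by MTT assay, with a stated time of 48 h (a lower number here means a stronger inhibitor of growth, a higher number a weaker inhibitor of growth), compound 2 `Oc1ccc(NC(=S)Nc2ccc3ncnc(Nc4cccc(Br)c4)c3c2)cc1` gives 17300 nM, the only true number so far. Compound 1 `Oc1cccc(Nc2ncnc3ccc(NC(=S)NCc4ccccc4)cc23)c1` gives only a limit, > 30000 nM. Compound 3 `O=S(=O)(Nc1nccs1)c1ccc(NC(=S)Nc2ccc3ncnc(Nc4cccc(Br)c4)c3c2)cc1` also gives only a limit, > 30000 nM. The measured picture is therefore bounded by the limit of > 30000 nM in this assay, at which 2 of the 3 values shown sit.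

Compound 4 `FC(F)(F)c1cc(NC(=S)Nc2ccc3ncnc(Nc4cccc(Br)c4)c3c2)ccc1Cl` carries 4-chloro-3-(trifluoromethyl)phenyl in place of 4-hydroxyphenyl on an amide-type nitrogen. Within the data shown here, one measured step bears on this change: an at least 1.7-fold higher number from compound 2 to compound 3 (0.23 log units; that floor lies within the scatter). That step alters the same aryl group, but it introduces a different substituent and its size is known only as a floor. Among the measured compounds shown here, it therefore offers no firm direction for the new group, and no measured pair tests the chloro or trifluoromethyl substituents.

For the measured compounds named here, with so little to go on, the expectation for this assay stays close to the one number available. The estimated step is a 1.4-fold lower number from compound 2 to compound 4 (0.16 log units; within the scatter), and no change beyond the scatter is expected. For compound 4 the estimated value is 12000 nM, with an expected range of 3000 nM to 30000 nM.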

Compound 4, concentration for 50% growth inhibition: 1100 nM
Compound 4: the middle estimate sits 11-fold (1.04 log units) above what was measured, and the stated range ends above it.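

In this assay, the aryl group on the amide-type nitrogen proves able to move the number well beyond the scatter: putting 4-chloro-3-(trifluoromethyl)phenyl in place of 4-hydroxyphenyl gives a 16-fold lower number from compound 2 to compound 4 (1.20 log units; beyond the scatter). Compound 3 carries a different group in the same place and gives > 30000 nM, a limit and not a number, and that comparison fixed no direction for this position. The entering group has 11 heavy atoms and 0 hydrogen-bond donors against 7 and 1 in the leaving group, but the hydroxy group is lost and both new substituents arrive in one step, so the step cannot be assigned to any one of these changes.

Still open, as far as these compounds go, is whether the chloro or the trifluoromethyl substituent alone would reproduce this step, and whether a group such as an amine or a carboxylic acid on the same phenyl would hold it or lose it. The wider picture for this series also remains tightly bounded: the limit of > 30000 nM in this assay, at which 2 of the 4 values shown sit.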